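A few compounds are considered here, and "the series" means these few. Any claim that something is new, unique, unknown or untested is made for them only; others in the source may bear on it.

Measured compounds:
compound 1, `NC(=O)c1c(NC(=O)c2ccccc2Cl)sc2c1CCN(Cc1cc(Cl)cc(Cl)c1)C2`: 23700 nM
compound 2, `NC(=O)c1c(NC(=O)c2ccc(C(F)(F)F)cc2)sc2c1CCN(Cc1ccccc1F)C2`: 26900 nM
compound 3, `NC(=O)c1c(NC(=O)c2cccc([N+](=O)[O-])c2)sc2c1CCN(Cc1ccc(Cl)cc1Cl)C2`: 16500 nM

All three share the same core and differ only in their side groups. In a functional assay on MKN-74 cells (Homo sapiens) for antiproliferative activity, with a stated time of 24 h (a lower number here means a stronger inhibitor, a higher number a weaker inhibitor), their three numbers lie within the usual scatter of one another, so compound 1 cannot be placed above or below compound 2 or compound 3; all three are weak inhibitors. Compound 4, `NC(=O)c1c(NC(=O)c2ccccc2Cl)sc2c1CCN(C(=O)Nc1c(Cl)cccc1Cl)C2`, has not yet been measured. It differs from compound 1 in one place: (2,6-dichlorophenyl)carbamoyl in place of 3,5-dichlorobenzyl on an amine nitrogen in a ring. Within the data shown here, no measured pair shows what such a change does, so there is no basis for a direction. The expected step, a 1.1-fold higher number from compound 1 to compound 4 (0.02 log units; within the scatter), is none beyond the scatter. In this assay compound 4 is therefore estimated at about 25000 nM, with a range from 8000 nM to 80000 nM.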

Compound 4, half-maximal inhibitory concentration: 24400 nM
Estimate against measurement, compound 4: 1.0-fold (0.01 log units) above, and the stated range covers the measured number.
By their numbers in this assay, from the lowest: compounds 3, 1, 4 and 2 (each within the scatter of the next).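

At this amine nitrogen in a ring, (2,6-dichlorophenyl)carbamoyl in place of 3,5-dichlorobenzyl gives a 1.0-fold higher number from compound 1 to compound 4 (0.01 log units; within the scatter) in this assay and so leaves the reading unmoved. The position therefore takes a group with a carbonyl and a hydrogen-bond donor without the number leaving the scatter, and compound 4 remains a weak inhibitor. Nothing available explains why these two groups read alike. On these data alone, whether a simple methyl or a chain ending in a carboxylic acid at this nitrogen would shift the number stays open. Also open, as far as these compounds go, is whether this swap would read the same with the side groups of compound 2 or compound 3.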